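The source may hold more compounds than are shown below. What is called first, only, known or untested is meant among the compounds shown, and "the series" means these compounds.

In a functional assay on A549 cells (Homo sapiens) for antiproliferative activity, read by MTT assay, with a stated time of 48 h (on this read-out lower numbers stand for stronger inhibition and higher numbers for weaker inhibition), compound 1 (`COc1ccc(C(=O)/C=C/c2cc(Br)cc(Br)c2Oc2c([N+](=O)[O-])cc(C(F)(F)F)cc2[N+](=O)[O-])cc1`) gives 13.2 ug/mL, compound 2 (`COc1ccc(C(=O)/C=C/c2cccc(Br)c2Oc2c([N+](=O)[O-])cc(C(F)(F)F)cc2[N+](=O)[O-])cc1`) gives 12.7 ug/mL and compound 3 (`COc1ccc(C(=O)/C=C/c2cccc(Cl)c2Oc2c([N+](=O)[O-])cc(C(F)(F)F)cc2[N+](=O)[O-])cc1`) gives 11.5 ug/mL. Compound 2 therefore stands within the scatter of both other compounds. Compound 4 (`O=C(/C=C/c1cccc(Br)c1Oc1c([N+](=O)[O-])cc(C(F)(F)F)cc1[N+](=O)[O-])c1ccc(Cl)cc1`) is still unmeasured, and its difference from compound 2 is chloro in place of methoxy on an aromatic carbon. Two measured steps offer only indirect guidance, a 1.0-fold lower number from compound 1 to compound 2 (0.02 log units; within the scatter) and a 1.1-fold lower number from compound 2 to compound 3 (0.04 log units; within the scatter). Both lie within the scatter, but both replace bromo and neither involves methoxy. No shift beyond the scatter is therefore expected in this assay, in either direction. The expected step is a 1.1-fold lower number from compound 2 to compound 4 (0.02 log units; within the scatter). For compound 4 the estimated value is 12 ug/mL, with an expected range of 6.5 ug/mL to 22 ug/mL.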

Compound 4, half-maximal inhibitory concentration: 16.5 ug/mL
The estimate for compound 4 lay 1.4-fold (0.14 log units) below the measured number, within the range that was stated.
By their numbers in this assay, from the lowest: compounds 3, 2, 1 and 4 (each within the scatter of the next).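

In this assay, within the data shown here, the first change at this position gives a 1.3-fold higher number from compound 2 to compound 4 (0.11 log units; within the scatter), so chloro in place of methoxy, para to a large group, does not move the number beyond the scatter. The earlier steps shown here replaced only bromo, so they said nothing about this place. No measurement bears on why the step is this small. As far as these compounds go, whether an amine or a carboxylic acid at this position would also stay within the scatter remains open. So does whether this step would hold with chloro instead of bromo elsewhere on the core.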